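Swapping Phenoxy for Carboxymethyl in a Cytotoxicity Series

This account rests on a few compounds, and the source may have more. Where it says the series, first, only, none or still open, it means among the compounds named here.

Of the compounds shown here, three have so far been tested in an ADME assay on HEK293 cells (Homo sapiens) for cytotoxicity, read by CellTiter-Glo and resazurin assay, with a stated time of 72 h (on this read-out higher numbers stand for an effect only at larger amounts of compound and lower numbers for an effect already at smaller amounts), and none of them gave a number. Compound 1 `CC(C)N(Cc1cccc(OCCCCCC(=O)O)c1)C(=O)c1ccc(-c2cccc(N(C)C)c2)cc1` gives > 26000 nM, which is a limit of the assay rather than a measured value. Compound 2 `CC(C)N(Cc1cccc(OCCCCCC(=O)O)c1)C(=O)c1ccc(-c2cccc(Oc3ccccc3)c2)cc1` gives > 18700 nM, again a limit. Compound 3 `CCOC(=O)CCCCCOc1cccc(CN(C(=O)c2ccc(-c3cccc(Oc4ccccc4)c3)cc2)C(C)C)c1` gives > 19600 nM, also a limit. The step that the two limits leave unreadable from compound 1 to compound 2 and the step that the two limits leave unreadable from compound 2 to compound 3 both run between two limits, so neither their size nor their direction can be read. Compound 3 therefore stands at the limit of > 19600 nM in this assay, at which 1 of the 3 values shown sits, alongside the two other values, which likewise sit at limits.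

Compound 4 `CCOC(=O)CCCCCOc1cccc(CN(C(=O)c2ccc(-c3cccc(CC(=O)O)c3)cc2)C(C)C)c1` differs from compound 3 by carboxymethyl in place of phenoxy on an aromatic carbon. Among the measured compounds shown here, no measured step in this set involves a carboxymethyl group, and the two measured steps that exist are unreadable, so there is nothing in the data pointing to a change beyond the scatter in either direction. The estimated step that the limit leaves unreadable from compound 3 to compound 4 is expected to stay within the scatter, with compound 4 most probably reported as a limit again. Compound 4 is accordingly expected to give about 25000 nM, within a range from 9000 nM to 80000 nM.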

Compound 4, half-maximal effective concentration: > 26000 nM
Compound 4 was reported as a limit; the forecaster's own chance of this, stated with the estimate: 80%; at least 1.0-fold (0.01 log units) between middle value and limit.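

In this assay compound 4 gives > 26000 nM, which is a limit of the assay. Compound 3 also stands at a limit, so the step from compound 3 to compound 4 cannot be read. The compounds shown leave open at what concentration any of the four would reach a half-maximal effect, and whether carboxymethyl in place of phenoxy changes it.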